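The source may report more compounds than this note shows. Statements on the series, on what has been measured and on what is new or still open speak of the compounds shown alone.

In a functional assay on MDA-MB-231 cells (Homo sapiens) for antiproliferative activity, read by CCK-8 assay, with a stated time of 48 h (a higher number here means a weaker inhibitor, a lower number a stronger inhibitor), compound 2 `COc1ccc2[nH]c(C)c(C3=C(Br)C(=O)C(c4c(-c5ccc(C)cc5)[nH]c5ccccc45)=C(Br)C3=O)c2c1` gives 3.99 ug/mL, while compound 1 `COc1ccc2[nH]c(C)c(C3=C(Br)C(=O)C(c4c(-c5ccccc5)[nH]c5ccccc45)=C(Br)C3=O)c2c1` gives 5.02 ug/mL; the two values lie within the scatter of each other. Within the data shown here, the one measured step, a 1.3-fold lower number from compound 1 to compound 2 (0.10 log units; within the scatter), concerns a methyl in place of hydrogen on an aromatic carbon. Compound 3 `COc1ccc2[nH]c(C)c(C3=C(Br)C(=O)C(c4c(C)[nH]c5ccccc45)=C(Br)C3=O)c2c1` differs from compound 2 by methyl in place of 4-methylphenyl on an aromatic carbon. Among the measured compounds shown here, no measured step removes the six-membered aromatic ring itself, so the step from compound 1 to compound 2 bears on this change only loosely. The number for compound 3 in this assay is expected to be 7 ug/mL, between 3 ug/mL and 16 ug/mL. That estimate means a 1.8-fold higher number from compound 2 to compound 3 (0.24 log units; within the scatter), an expected step barely beyond the scatter.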

Compound 3, half-maximal inhibitory concentration: > 10 ug/mL
Compound 3 gave a limit, no number (the forecaster's own chance of this, stated with the estimate: 5%); middle value at least 1.4-fold (0.15 log units) from the limit.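

Compound 3 gives a limit, not a number, in this assay: the limit of > 10 ug/mL in this assay, at which 1 of the 3 values shown sits.

Methyl in place of 4-methylphenyl, on this aromatic carbon next to the ring nitrogen, gives an at least 2.5-fold higher number from compound 2 to compound 3 (0.39 log units; beyond the scatter), so losing the six-membered aromatic ring here produces a step that the methyl change on that ring did not. Methyl in place of phenyl gives an at least 1.9-fold higher number from compound 1 to compound 3 (0.29 log units; that floor lies within the scatter), so this pair alone does not establish a loss.

The limit leaves the full size of both steps open. From the compounds shown here alone, whether a cyclohexyl group or a longer chain such as butyl would behave like the aromatic groups or like methyl also remains open.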